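Secondary versus tertiary amide in the shared core

The source may report more compounds than this note shows. Statements on the series, on what has been measured and on what is new or still open speak of the compounds shown alone.

Compound 1 `CNC(=O)/C=C1\CCc2cc(F)c(F)cc21`: 96 mg/kg
Compound 2 `CCCNC(=O)/C=C1\CCc2ccc(F)cc21`: > 100 mg/kg

In a functional assay on the whole organism with Mus musculus as the target (a higher number here means that more compound is needed for the effect, a lower number that less compound is needed), compound 1 gives 96 mg/kg. Compound 2 gives only a limit of the assay, > 100 mg/kg, so no exact number is known for it; this is the limit of > 100 mg/kg in this assay, at which 1 of the 2 values shown sits. The unmeasured compound 3 `CCN(C)C(=O)/C=C1\CCc2ccc(F)cc21` differs from compound 2 by ethyl(methyl)amino in place of propylamino on a carbonyl carbon. With no measured step of this kind in hand, the change is expected to move this assay by no more than the usual scatter, in no firm direction. The step from compound 2 to compound 3 is estimated as a step that the limit leaves unreadable from compound 2 to compound 3. Compound 3 is expected to give 150 mg/kg, within 60 mg/kg to 350 mg/kg.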

Compound 3, dose for half-maximal effect: 100 mg/kg
The estimate for compound 3 lay 1.5-fold (0.18 log units) above the measured number, and the stated range covers the measured number.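

In this assay, ethyl(methyl)amino in place of propylamino on a carbonyl carbon, a change that gives up the amide hydrogen, yields a number no higher from compound 2 to compound 3 (the limit leaves the size open). Going by these compounds alone, a tertiary amide at this place therefore needs a dose no higher than the secondary amide of compound 2, a reading the earlier compounds did not offer. The size of the step cannot be read because compound 2 stands at a limit of the assay: the limit of > 100 mg/kg in this assay, at which 1 of the 3 values shown sits. From the compounds shown here alone, it remains open how large the step truly is, and whether a cyclic amine such as morpholine on the same carbonyl carbon would shift the dose.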